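From propylamino to piperidin-1-yl on a carbonyl carbon

This account rests on a few compounds, and the source may have more. Where it says the series, first, only, none or still open, it means among the compounds named here.

Three related compounds have been tested in a functional assay on Huh-5-2 cells (Homo sapiens), read by MTT assay; a lower number here means that less compound is tolerated, a higher number that more compound is tolerated. Compound 1 (`N#Cc1ccc(-c2ccc(Cl)cc2)c(COc2ccc(-c3nc4cc(C(=O)O)ccc4n3C3CCCCC3)cc2)c1`) gives 23000 nM, compound 2 (`Cc1nc(-c2ccc(Cl)cc2)c(COc2ccc(-c3nc4cc(C(=O)O)ccc4n3C3CCCCC3)cc2)s1`) gives 39000 nM, and compound 3 (`CCCNC(=O)c1ccc(-c2ccc(Cl)cc2)c(COc2ccc(-c3nc4cc(C(=O)O)ccc4n3C3CCCCC3)c(F)c2)c1`) gives 24000 nM. Compound 3 lies within the usual scatter of repeated measurements of both others, so these three numbers cannot be ranked.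

Compound 4 (`O=C(O)c1ccc2c(c1)nc(-c1ccc(OCc3cc(C(=O)N4CCCCC4)ccc3-c3ccc(Cl)cc3)cc1F)n2C1CCCCC1`) has not been measured yet. It departs from compound 3 in one place, with piperidin-1-yl in place of propylamino on a carbonyl carbon. Among the compounds with values here, no two measured compounds differ in just one place, so the data hold no direct precedent for this swap. Even so, compound 1 and compound 3 differ in more than one place, and compound 1 at 23000 nM stays within the scatter of compound 3 at 24000 nM. In this assay, a change beyond the scatter is therefore not expected. The expected size of the step of a 1.1-fold higher number from compound 3 to compound 4 (0.03 log units; within the scatter) is small. The estimate for compound 4 is 26000 nM, within a range of 13000 nM to 50000 nM.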

Compound 4, half-maximal cytotoxic concentration: 24000 nM
Compound 4: middle estimate off by 1.1-fold (0.03 log units), on the high side; the range from low to high includes it.
By their numbers in this assay, from the lowest: compounds 1, 3, 4 and 2 (each within the scatter of the next).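

In this assay, within the data shown here, putting piperidin-1-yl in place of propylamino on a carbonyl carbon gives no change at the digits printed from compound 3 to compound 4 (within the scatter), and this is the only step in the set that changes a single place. Among these compounds, it gives the first direct reading at this position: the amide hydrogen of compound 3 is gone in compound 4 and a six-membered non-aromatic ring has entered, yet the two numbers cannot be told apart. Nothing available explains this result.

From the compounds shown here alone, whether the same carbonyl carbon would give a similar reading with morpholin-4-yl, which brings a ring oxygen, or with a longer chain such as hexylamino remains open. Also open, going by these compounds, is whether this swap would read the same on a core without the fluorine shared by compound 3 and compound 4.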